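A few compounds are considered here, and "the series" means these few. Any claim that something is new, unique, unknown or untested is made for them only; others in the source may bear on it.

In a functional assay on HeLa cells (Homo sapiens) for cytotoxicity, read by MTT assay, with a stated time of 24 h (on this read-out higher numbers stand for weaker inhibition and lower numbers for stronger inhibition), three compounds have been measured:
Compound 1 `COc1ccc(/C=C2\CN(C)C/C(=C\c3ccccc3F)C2=O)cc1OC` gives 14400 nM
Compound 2 `COc1cc(/C=C2\CN(C)C/C(=C\c3ccccc3F)C2=O)cc(OC)c1` gives 5450 nM
Compound 3 `COc1cc(/C=C2\CN(C)C/C(=C\c3ccccc3F)C2=O)cc(OC)c1OC` gives 3220 nM

Compound 3 stands at the low end of these numbers: a 4.5-fold lower number from compound 1 to compound 3 (0.65 log units; beyond the scatter) is beyond the scatter, whereas a 1.7-fold lower number from compound 2 to compound 3 (0.23 log units; within the scatter) is within it. Compound 4 (`COc1cc(/C=C2\CN(C)C/C(=C\c3cc(OC)c(OC)c(OC)c3)C2=O)cc(OC)c1`) brings a different kind of change (3,5-dimethoxyphenyl in place of 2-fluorophenyl on a double-bonded chain carbon bound to a double-bonded ring carbon) on a double-bonded chain carbon bound to a double-bonded ring carbon. Among the measured compounds shown here, no measured step alters that group. Both measured steps put methoxy in place of hydrogen on an aromatic carbon elsewhere in the molecule, so they bear on this change only loosely, and the larger one is modest. No shift beyond the scatter is therefore expected in this assay for this change. The estimated step is a 1.2-fold higher number from compound 3 to compound 4 (0.09 log units; within the scatter) and no more than that. Compound 4 is estimated at 4000 nM with 1300 nM to 12000 nM as its expected range.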

Compound 4, half-maximal inhibitory concentration: 2300 nM
Estimate against measurement, compound 4: 1.7-fold (0.24 log units) above, and the stated range covers the measured number.
By their numbers in this assay, from the lowest: compounds 4, 3 and 2 (each within the scatter of the next, the first and the last beyond it); then compound 1.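

In this assay, the exchange of 2-fluorophenyl for 3,5-dimethoxyphenyl on a double-bonded chain carbon bound to a double-bonded ring carbon gives a 1.4-fold lower number from compound 3 to compound 4 (0.15 log units; within the scatter). This first reading at this position shows that the fluorine-bearing ring can give way to one carrying two hydrogen-bond acceptors without a shift beyond the scatter. No measured evidence bears on why this is so. The compounds shown leave open how an amine or a carboxylic acid on this ring would read, and whether a plain phenyl would read the same.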